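This account rests on a few compounds, and the source may have more. Where it says the series, first, only, none or still open, it means among the compounds named here.

Values measured so far in a functional assay on HCT-116 cells (Homo sapiens) for cytotoxicity, read by MTT assay, with a stated time of 72 h; a lower number here means a stronger inhibitor, a higher number a weaker inhibitor:

- Compound 1 `N[C@H]1CC[C@H](Nc2c(C(=O)NCc3ccc(F)cc3)nc(Br)c3cccnc23)CC1`: 7000 nM
- Compound 2 `C[C@H](NC(=O)c1nc(Br)c2cccnc2c1N[C@H]1CC[C@H](N)CC1)c1ccc(F)cc1`: > 10000 nM (a limit of the assay, not a number)

Where compound 2 stands is known only as the limit of > 10000 nM in this assay, at which 1 of the 2 values shown sits. The next structure is compound 3 `N[C@H]1CC[C@H](Nc2c(C(=O)NCc3ccc(Cl)cc3)nc(Br)c3cccnc23)CC1`, and the change leading to it is 4-chlorobenzyl in place of 1-(4-fluorophenyl)ethyl on an amide-type nitrogen. In words, 4-chlorobenzyl takes the place of 1-(4-fluorophenyl)ethyl on an amide-type nitrogen.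

For the measured compounds named here, one measured step bears on this change. Going to compound 2, a methyl replaces hydrogen on a saturated chain carbon bound to an amide-type nitrogen and an aromatic carbon, and the result is an at least 1.4-fold higher number from compound 1 to compound 2 (0.15 log units; that floor lies within the scatter). The new change removes that methyl, so this step applies in reverse, but its size is known only as a floor. Going by the values given here, the swap of fluorine for chlorine has no measured step of its own. A modest move toward a lower number is therefore expected in this assay, and it may not exceed the scatter.

The estimated step is an at least 1.6-fold lower number from compound 2 to compound 3 (0.22 log units; that floor lies within the scatter). For compound 3 the expected value is 6000 nM, with an expected range from 2500 nM to 12000 nM.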

Compound 3, half-maximal inhibitory concentration: 4000 nM
The estimate for compound 3 lay 1.5-fold (0.18 log units) above the measured number; the measured number falls inside the stated range.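

In this assay, for the compounds shown here, putting 4-chlorobenzyl in place of 1-(4-fluorophenyl)ethyl on the amide-type nitrogen gives an at least 2.5-fold lower number from compound 2 to compound 3 (0.39 log units; beyond the scatter) and so provides the first step at this position that clears the usual scatter of repeated measurements. Compound 2 stands at a limit of the assay, not a number, so that step is only a floor: the limit of > 10000 nM in this assay, at which 1 of the 3 values shown sits. The comparison that changes the aromatic substituent alone, chloro in place of fluoro, gives a 1.8-fold lower number from compound 1 to compound 3 (0.24 log units; within the scatter) and so shows that this swap on its own does not separate the two compounds in this assay.

The compounds shown leave open how a methoxy or a trifluoromethyl group would read in place of the chloro on the aromatic carbon, since only two halogens appear there. Going by these compounds alone, they also leave open how a methyl on the saturated chain carbon would read with chloro on the ring, as that methyl has been seen only with fluoro and with a result that is a limit.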